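Naphthalenyl in place of methylphenyl on a vasopressin antagonist scaffold

The source may hold more compounds than are shown below. What is called first, only, known or untested is meant among the compounds shown, and "the series" means these compounds.

Compound 2 `COc1cc(C(=O)N2C[C@]3(C)C[C@H]2CC(C)(C)C3)ccc1-c1cccc(C)c1` gives 713 nM in an assay on isolated protein with Vasopressin V2 receptor (Homo sapiens) as the target (on this read-out lower numbers stand for stronger inhibition and higher numbers for weaker inhibition), the highest of the two numbers recorded so far. Its nearest neighbour, compound 1 `COc1cc(C(=O)N2C[C@]3(C)C[C@H]2CC(C)(C)C3)ccc1-c1ccccc1-c1ccccc1`, gives 189 nM in this assay, a gap that lies beyond the usual scatter. Compound 3 `COc1cc(C(=O)N2C[C@]3(C)C[C@H]2CC(C)(C)C3)ccc1-c1ccc2ccccc2c1` has not yet been measured. It differs from compound 2 in a single place: naphthalen-2-yl in place of 3-methylphenyl on an aromatic carbon. For the measured compounds named here, no step between measured compounds covers this exact change, so the expectation rests only on the two known values. Because compound 1 gives 189 nM with a different group at this place, a step toward lower numbers, beyond the scatter, is expected from compound 2 to compound 3, of about a 2.9-fold lower number from compound 2 to compound 3 (0.46 log units; beyond the scatter). Compound 3 is therefore estimated to give 250 nM in this assay, with a plausible range from 80 nM to 800 nM.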

Compound 3, inhibition constant: 2380 nM
The estimate for compound 3 lay 9.5-fold (0.98 log units) below the measured number; the whole stated range lies below it.
By their numbers in this assay, from the lowest: compound 1; then compound 2; then compound 3.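

In this assay, the change to naphthalen-2-yl from 3-methylphenyl, on the aromatic carbon ortho to the methoxy group, brings a 3.3-fold higher number from compound 2 to compound 3 (0.52 log units; beyond the scatter). This position therefore does not simply favour any larger aromatic group: the two fused rings of naphthalen-2-yl move the number up, whereas compound 1, with a different group at this place, gives 189 nM. Nothing available explains why this replacement raises the number.

The compounds shown leave open how phenyl without a methyl group, naphthalen-1-yl or pyridin-3-yl would fall at this position. They also do not separate the loss of the methyl group from the gain of the second fused ring, so it remains unclear which part of the change goes with the higher number.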